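A Trifluoromethyl Group on a Compound at the Assay Limit

A few compounds are considered here, and "the series" means these few. Any claim that something is new, unique, unknown or untested is made for them only; others in the source may bear on it.

Going by the values given here, compound 1 (`O=[N+]([O-])c1ccc(COc2ccc(Nc3ncnc4cc5c(cc34)OCCOCCO5)cc2)cc1`) gives 8620 nM in a functional assay on A549 cells (Homo sapiens) for antiproliferative activity, read by MTT assay, with a stated time of 72 h (on this read-out lower numbers stand for stronger inhibition and higher numbers for weaker inhibition), and is the only compound here with an actual number. Compound 2 (`c1ccc(COc2ccc(Nc3ncnc4cc5c(cc34)OCCOCCOCCO5)cc2)cc1`) gives > 100000 nM in this assay as its reading, which is a limit and not a number. Compound 2 therefore stands at the weak end of the readings, with no exact value.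

Compound 3 (`FC(F)(F)c1ccc(COc2ccc(Nc3ncnc4cc5c(cc34)OCCOCCOCCO5)cc2)cc1`) differs from compound 2 in one place (trifluoromethyl in place of hydrogen on an aromatic carbon): trifluoromethyl in place of hydrogen on an aromatic carbon, para to a large group. Among the compounds with values here, no measured step shows what such a change does, so any expectation is loose. A modest move towards lower numbers in this assay is expected, and compound 3 could also remain at the limit. The expected change is an at least 2.8-fold lower number from compound 2 to compound 3 (0.45 log units; beyond the scatter) in this estimate. Within the data shown here, the reading of compound 1, 8620 nM, is the only number for comparison, and compound 3 is expected to stay on the weaker side of it. For compound 3 the estimate is 35000 nM and the expected range runs from 10000 nM to 100000 nM at its two ends.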

Compound 3, half-maximal inhibitory concentration: 30700 nM
The estimate for compound 3 lay 1.1-fold (0.06 log units) above the measured number; the measured number falls inside the stated range.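

Placing a trifluoromethyl group on an aromatic carbon, para to a large group, lifts this structure off the assay limit and gives it a readable number in this assay, with the change amounting to an at least 3.2-fold lower number from compound 2 to compound 3 (0.51 log units; beyond the scatter) and not merely a shift too small to tell from scatter. Going by these compounds alone, this is the first sign that the outer benzyl end of these molecules is a place where a single substitution can register in this read-out, something compound 1 and compound 2 could not show because they differ from each other in more than one place. Going by these compounds, the true size of the step remains unknown, and the figure is only a lower bound, because the reading for compound 2 is a limit and not a number: the limit of > 100000 nM in this assay, at which 1 of the 3 values shown sits.

On these data alone, it remains open whether this gain is particular to trifluoromethyl, or whether a methyl group, a chlorine atom, an amine or a carboxylic acid at the same place would do the same. Compound 1 differs from compound 3 in more than one place, so the compounds shown cannot say how the same substitution behaves on a different core.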